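The source may hold more compounds than are shown below. What is called first, only, known or untested is meant among the compounds shown, and "the series" means these compounds.

In a functional assay on U-251 cells (Homo sapiens) for inhibition, read by sulforhodamine B assay, with a stated time of 48 h (a lower number here means a stronger inhibitor of growth, a higher number a weaker inhibitor of growth), three compounds have been measured:
compound 1, `COc1cc(-c2nn(-c3cccc(NC(=O)Nc4ccc(Cl)c(Cl)c4)c3)cc2-c2ccncc2)ccc1Cl`, which gives 820 nM;
compound 2, `O=C(Nc1cccc(-n2cc(-c3ccncc3)c(-c3ccc(Cl)c(O)c3)n2)c1)Nc1ccc(Cl)c(Cl)c1`, which gives 1510 nM;
compound 3, `COc1cc(-c2nn(-c3cccc(NC(=O)Nc4ccc(Cl)c(C(F)(F)F)c4)c3)cc2-c2ccncc2)ccc1Cl`, which gives 985 nM.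

Compound 2 differs from compound 1 by hydrogen in place of methyl on an oxygen on an aromatic ring, and this gave a 1.8-fold higher number from compound 1 to compound 2 (0.27 log units; within the scatter). Compound 3 differs from compound 1 in its core by trifluoromethyl in place of chloro on an aromatic carbon, giving a 1.2-fold higher number from compound 1 to compound 3 (0.08 log units; within the scatter). Compound 4, `O=C(Nc1cccc(-n2cc(-c3ccncc3)c(-c3ccc(Cl)c(O)c3)n2)c1)Nc1ccc(Cl)c(C(F)(F)F)c1`, has not yet been measured in this assay; it differs from compound 3 by hydrogen in place of methyl on an oxygen on an aromatic ring. The place of this change is described in the same words as for the change from compound 1 to compound 2, so it is the same change, made on the other core. For compound 4 the expected step is a 1.8-fold higher number from compound 3 to compound 4 (0.26 log units; within the scatter), which rests on the measured 1.8-fold higher number from compound 1 to compound 2 (0.27 log units; within the scatter). Compound 4 is therefore estimated at 1800 nM in this assay, expected to fall between 900 nM and 3600 nM.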

Compound 4, concentration for 50% growth inhibition: 548 nM
The estimate for compound 4 lay 3.3-fold (0.52 log units) above the measured number, outside the stated range (below it).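

In this assay, hydroxy in place of methoxy gave a 1.8-fold lower number from compound 3 to compound 4 (0.25 log units; within the scatter), which does not match the earlier step for the same change: the same change on two cores in this assay, a 1.8-fold higher number (0.27 log units; within the scatter) from compound 1 to compound 2 and a 1.8-fold lower number (0.25 log units; within the scatter) from compound 3 to compound 4, 3.3-fold (0.52 log units) apart, beyond the scatter of two such steps. Trifluoromethyl in place of chloro, made where the hydroxy group is present, gave a 2.8-fold lower number from compound 2 to compound 4 (0.44 log units; beyond the scatter), and this also does not match its earlier step: the same change on two cores in this assay, a 1.2-fold higher number (0.08 log units; within the scatter) from compound 1 to compound 3 and a 2.8-fold lower number (0.44 log units; beyond the scatter) from compound 2 to compound 4, 3.3-fold (0.52 log units) apart, beyond the scatter of two such steps. Neither change can therefore be carried from one core to another in this set with its size unchanged, but four compounds do not show what lies behind this mismatch or whether it would hold in further pairs.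

On these data alone, it remains open how an amine or a longer alkoxy chain in place of the methoxy would behave on either core.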